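Amide to sulfonamide swap on the anilide series

This account rests on a few compounds, and the source may have more. Where it says the series, first, only, none or still open, it means among the compounds named here.

Measured so far in a functional assay on MCF7 cells (Homo sapiens) for antiproliferative activity, read by MTT assay, with a stated time of 48 h; on this read-out higher numbers stand for weaker inhibition and lower numbers for stronger inhibition:
compound 1, `O=C(Nc1cccc(/C=C/C(=O)c2nc3ccccc3[nH]2)c1)c1cccc(Cl)c1`, gives 7840 nM
compound 2, `COc1cccc(C(=O)Nc2cccc(/C=C/C(=O)c3nc4ccccc4[nH]3)c2)c1`, gives 17800 nM
compound 3, `COc1ccc(C(=O)Nc2cccc(/C=C/C(=O)c3nc4ccccc4[nH]3)c2)cc1`, gives 20100 nM

Compound 3 stands at the highest number of the three in this assay; its gap to compound 2 is within the scatter, whereas a 2.6-fold higher number from compound 1 to compound 3 (0.41 log units; beyond the scatter) is beyond it. Compound 4, `O=C(/C=C/c1cccc(NS(=O)(=O)c2cccc(Cl)c2)c1)c1nc2ccccc2[nH]1`, differs from compound 3 in one place: (3-chlorophenyl)sulfonyl in place of (4-methoxyphenyl)carbonyl on a nitrogen on an aromatic ring.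

Within the data shown here, two measured steps bear on this. a 2.6-fold higher number from compound 1 to compound 3 (0.41 log units; beyond the scatter) covers the same aryl swap in the opposite direction, with 3-chlorophenyl giving the lower number; a 2.3-fold higher number from compound 1 to compound 2 (0.36 log units; beyond the scatter) points the same way. The 3-chlorophenyl arm is therefore expected to bring the number back down toward that of compound 1. Among the measured compounds shown here, no measured pair shows a carbonyl replaced by a sulfonyl on that nitrogen, so that part of the change is uncovered by the data and widens the range rather than setting a direction. Taken together, a modest drop from compound 3 is expected, a 2.0-fold lower number from compound 3 to compound 4 (0.30 log units; within the scatter). The estimate for compound 4 in this assay is 10000 nM, with a range from 3000 nM to 30000 nM.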

Compound 4, half-maximal inhibitory concentration: 4160 nM
Estimate against measurement, compound 4: 2.4-fold (0.38 log units) above, within the range that was stated.
By their numbers in this assay, from the lowest: compounds 4 and 1 (each within the scatter of the next); then compounds 2 and 3 (each within the scatter of the next).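

On the nitrogen on an aromatic ring, carbonyl and sulfonyl can now be compared with the 3-chlorophenyl arm held fixed: in this assay that swap gives a 1.9-fold lower number from compound 1 to compound 4 (0.28 log units; within the scatter), so the sulfonyl is accepted at this position with no difference beyond the scatter. The larger steps, a 4.8-fold lower number from compound 3 to compound 4 (0.68 log units; beyond the scatter) and a 4.3-fold lower number from compound 2 to compound 4 (0.63 log units; beyond the scatter), each alter the aryl group and the linking group together, so neither can be assigned to the linking group alone; read with the matched pair, they suggest that among these compounds the aryl swap matters more than the swap of carbonyl for sulfonyl. No measurement at hand explains why the sulfonyl is accepted here.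

The compounds shown carry the sulfonyl only with 3-chlorophenyl, so it remains open whether a 3-methoxyphenyl or 4-methoxyphenyl arm on the sulfonyl would track the numbers of its carbonyl counterparts, compound 2 and compound 3. Also open, from the compounds shown here alone, is how an amine or a carboxylic acid on the aryl ring, or a longer chain in place of that ring on the sulfonyl, would read at this nitrogen.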